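Swapping a Methoxyphenyl for a Chlorofluorophenyl: Expected Tolerance

The source may hold more compounds than are shown below. What is called first, only, known or untested is meant among the compounds shown, and "the series" means these compounds.

Going by the values given here, the three compounds measured so far share one core and differ only in the group on an aromatic carbon. Compound 1 `COc1nc(-c2cnsc2)ccc1[C@@H](c1ccccc1)[C@@](O)(CCN(C)C)c1cccc2ccccc12` carries a 1,2-thiazol-4-yl group; in a toxicity assay on HeLa cells (Homo sapiens) for cytotoxicity (a lower number here means that less compound is tolerated, a higher number that more compound is tolerated), compound 1 gives 28.8 ug/mL. Compound 2 `COc1nc(-c2ccc(F)cc2)ccc1[C@@H](c1ccccc1)[C@@](O)(CCN(C)C)c1cccc2ccccc12` carries a 4-fluorophenyl group instead, and in this assay compound 2 reaches only a limit of the assay, > 64 ug/mL. On these data alone, compound 3 `COc1ccc(-c2ccc([C@@H](c3ccccc3)[C@@](O)(CCN(C)C)c3cccc4ccccc34)c(OC)n2)cc1` carries a 4-methoxyphenyl group; in this assay compound 3 likewise sits at a limit, > 64 ug/mL, so where it truly stands beyond that is unknown. The step of an at least 2.2-fold higher number from compound 1 to compound 2 (0.34 log units; beyond the scatter) and the step of an at least 2.2-fold higher number from compound 1 to compound 3 (0.34 log units; beyond the scatter) are both at least modest rises, while the step that the two limits leave unreadable from compound 2 to compound 3 cannot be read because of the limit of > 64 ug/mL in this assay, at which 2 of the 3 values shown sit.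

Compound 4 `COc1nc(-c2ccc(Cl)c(F)c2)ccc1[C@@H](c1ccccc1)[C@@](O)(CCN(C)C)c1cccc2ccccc12` differs from compound 3 in one place: 4-chloro-3-fluorophenyl in place of 4-methoxyphenyl on an aromatic carbon. Among the compounds with values here, both measured steps that raised tolerance moved from the 1,2-thiazol-4-yl group to a phenyl group; the one phenyl-to-phenyl comparison is unreadable. Compound 4 keeps a phenyl group, so it is expected to remain near the limit, with the step of an at least 1.1-fold lower number from compound 3 to compound 4 (0.06 log units; that floor lies within the scatter) estimated to be small. Compound 4 is estimated at 55 ug/mL, within 22 ug/mL to 100 ug/mL.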

Compound 4, half-maximal cytotoxic concentration: > 64 ug/mL
Compound 4: only a limit was reported; the forecaster's own chance of this, stated with the estimate: 55%; middle value at least 1.1-fold (0.06 log units) away from the limit.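

In this assay compound 4 gives > 64 ug/mL, which is a limit of the assay rather than a number. Leaving the 1,2-thiazol-4-yl group for a phenyl group now gives the same kind of rise a third time, at this position next to the ring nitrogen, as an at least 2.2-fold higher number from compound 1 to compound 4 (0.34 log units; beyond the scatter) shows, and carrying both chlorine and fluorine on the phenyl ring does not bring the number back down to a readable value. The steps among compound 2, compound 3 and compound 4 cannot be read because all three share one limit: the limit of > 64 ug/mL in this assay, at which 3 of the 4 values shown sit.

On these data alone, how far beyond that limit each of these three compounds lies remains open. Also open, as far as these compounds go, is whether an amine or a carboxylic acid in this place would keep the number at the limit or bring it towards that of compound 1.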